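The compounds below may be only part of what the source reports. "The series", "measured", "known", "first", "only" and "open" are said of these compounds alone.

Measured in a functional assay on A375P cells (Homo sapiens) for inhibition, read by MTT assay, with a stated time of 24 h; on this read-out higher numbers stand for weaker inhibition of growth and lower numbers for stronger inhibition of growth:
- Compound 1 `Cc1cn(-c2cc(C(=O)Nc3ccc(C4=Nc5cnn(Cc6ccccc6)c5NC(=O)C4)cc3)cc(C(F)(F)F)c2)cn1`: > 30000 nM (a limit, not a number)
- Compound 2 `COc1ccc(Cn2ncc3c2NC(=O)CC(c2cccc(NC(=O)Nc4cccc(Cl)c4)c2)=N3)cc1`: 910 nM
- Compound 3 `COc1ccc(Cn2ncc3c2NC(=O)CC(c2cccc(NC(=O)Nc4ccc(Cl)cc4)c2)=N3)cc1`: 640 nM

Only compound 2 and compound 3 give real numbers here, and the two cannot be told apart: a 1.4-fold lower number from compound 2 to compound 3 (0.15 log units; within the scatter). Compound 3 therefore stands level with compound 2, while compound 1 reaches only a limit, (the limit of > 30000 nM in this assay, at which 1 of the 3 values shown sits).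

Compound 4 `O=C1CC(c2cccc(NC(=O)Nc3ccc(Cl)cc3)c2)=Nc2cn[nH]c2N1` keeps the rest of compound 3 but has hydrogen in place of 4-methoxybenzyl on an aromatic nitrogen.

Among the compounds with values here, no measured step tests this change. Within the data shown here, the single step available swaps 3-chlorophenyl for 4-chlorophenyl, a different place in the molecule, and it stays within the scatter. Compound 1 differs from compound 3 in several places, so its limit cannot be traced to any one group. What remains is a judgement: the whole group is lost, and each of the measured compounds carries a benzyl-type group on that nitrogen, compound 3 with 640 nM among them. A clear loss of growth inhibition in this assay therefore seems more likely than no change, though the size is very uncertain.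

The expected change is a 4.7-fold higher number from compound 3 to compound 4 (0.67 log units; beyond the scatter).

For compound 4 the estimated value is 3000 nM, with an expected range from 500 nM to 25000 nM.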

Compound 4, concentration for 50% growth inhibition: > 30000 nM
Compound 4 ended at the assay's limit; the forecaster's own chance of this, stated with the estimate: 25%; middle value at least 10-fold (1.00 log units) away from the limit.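

In this assay compound 4 gives > 30000 nM, which is a limit of the assay and not a number. Hydrogen in place of 4-methoxybenzyl is the first measured change on this aromatic nitrogen, and it brings an at least 46-fold higher number from compound 3 to compound 4 (1.67 log units; beyond the scatter), a large step whose full size stays unknown, whereas the only earlier step, a 1.4-fold lower number from compound 2 to compound 3 (0.15 log units; within the scatter), concerned the chlorine on the far phenyl ring. So growth inhibition by compound 3 does not survive the loss of the whole group, and compound 4 now stands with compound 1, which differs from compound 3 in several places and so says nothing about this change: the limit of > 30000 nM in this assay, at which 2 of the 4 values shown sit.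

The compounds shown leave open which part of 4-methoxybenzyl counts, since hydrogen removes the whole group at once, including its ring and its methoxy group. A plain benzyl group, a methyl group or a longer chain such as butyl on the same nitrogen of compound 3 would show whether the ring, the methoxy group or simply something larger than hydrogen is needed there.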